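The compounds below may be only part of what the source reports. "The series", "measured", "known", "first", "only" and "open" are said of these compounds alone.

Measured in a functional assay on MCF7 cells (Homo sapiens) for antiproliferative activity, read by sulforhodamine B assay, with a stated time of 3 days; a higher number here means a weaker inhibitor, a lower number a stronger inhibitor:

Compound 1 `c1ccc(Sc2ncnc3[nH]cnc23)cc1`: 31000 nM
Compound 2 `Clc1ccc(Sc2ncnc3c2ncn3C2COc3ccccc3CO2)c(Cl)c1`: 12000 nM

Compound 2 has the lower of the two numbers, which makes it the stronger inhibitor of the pair, and its gap to compound 1 lies beyond the usual scatter. Compound 3 `CSc1ncnc2c1ncn2C1COc2ccccc2CO1` has not yet been measured. It keeps the rest of compound 2 and changes one group, with methyl in place of 2,4-dichlorophenyl on a sulfur.

Within the data shown here, no two measured compounds differ in just one place, so this change has no direct precedent here. Among the measured compounds shown here, the only guide is the range the two measured compounds span, with compound 2 at 12000 nM and compound 1 at 31000 nM. A moderate move towards a higher number, meaning a weaker inhibitor, is therefore expected in this assay, although a result within the scatter of compound 2 would be no surprise. The expected change is a 2.1-fold higher number from compound 2 to compound 3 (0.32 log units; beyond the scatter). For compound 3 the estimated value is 25000 nM, within an expected range from 9000 nM to 70000 nM.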

Compound 3, half-maximal inhibitory concentration: 24000 nM
Estimate against measurement, compound 3: 1.0-fold (0.02 log units) above; measured number inside the range.
By their numbers in this assay, from the lowest: compounds 2, 3 and 1 (each within the scatter of the next, the first and the last beyond it).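

Among these compounds, this is the first pair here that differs in one place only, so it gives the first direct reading of the group on the sulfur. In this assay, replacing 2,4-dichlorophenyl with methyl gives a 2.0-fold higher number from compound 2 to compound 3 (0.30 log units; within the scatter), which means the two compounds cannot be told apart in this assay. For this pair, then, the aromatic ring and its two chlorine atoms can go, leaving only a methyl on the sulfur, without a difference that stands clear of ordinary repeat-to-repeat variation, although nothing measured here explains that outcome.

The compounds shown leave open whether any other group on the sulfur would separate from these two, such as an unsubstituted phenyl, a longer chain like n-butyl, or a chain ending in an amine or a carboxylic acid. They also leave open what the group on the ring nitrogen contributes, since compound 1 differs from compound 2 and from compound 3 in more than one place and so cannot isolate that part of the structure.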